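The compounds below may be only part of what the source reports. "The series", "measured", "known", "first", "only" and "open" are said of these compounds alone.

In an assay on isolated protein for displacement of a labelled ligand from Apoptosis regulator Bcl-2 (Homo sapiens), read by fluorescence polarization (a lower number here means a stronger inhibitor, a higher number a weaker inhibitor), compound 1 `CN(C)CC[C@H](CSc1ccccc1)Nc1ccc(S(=O)(=O)NC(=O)c2ccc(N3CCN(CC4=C(c5ccc(Cl)cc5)CCCCC4)CC3)cc2)cc1[N+](=O)[O-]` gives < 1 nM, which is a limit of the assay rather than a number. Compound 3 `CN(C)CC[C@H](CSc1ccccc1)Nc1ccc(S(=O)(=O)NC(=O)c2ccc(N3CCN(CC4=C(c5ccc(Cl)cc5)CCOC4)CC3)cc2)cc1[N+](=O)[O-]` gives 2.4 nM in this assay. Compound 2 `CN(C)CC[C@H](CSc1ccccc1)Nc1ccc(S(=O)(=O)NC(=O)c2ccc(N3CCN(Cc4ccccc4-c4ccc(Cl)cc4)CC3)cc2)cc1S(C)(=O)=O` gives < 1 nM in this assay, again a limit of the assay and not a number. That position is the limit of < 1 nM in this assay, at which 2 of the 3 values shown sit, shared with compound 1. Compound 4 `CN(C)CC[C@H](CSc1ccccc1)Nc1ccc(S(=O)(=O)NC(=O)c2ccc(N3CCN(Cc4ccccc4-c4ccc(Cl)cc4)CC3)cc2)cc1C(=O)C(F)(F)F` differs from compound 2 by (trifluoromethyl)carbonyl in place of methylsulfonyl on an aromatic carbon. Going by the values given here, no measured pair carries this change, so no step size is known for it. Compound 4 is expected to remain close to the limit, the step from compound 2 to compound 4 being estimated as an at least 1.2-fold higher number from compound 2 to compound 4 (0.07 log units; that floor lies within the scatter), within the scatter. The estimate for compound 4 in this assay is 1.2 nM, between 0.3 nM and 5 nM.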

Compound 4, inhibition constant: < 1 nM
Compound 4: no number, only a limit; the forecaster's own chance of this, stated with the estimate: 45%; middle value at least 1.2-fold (0.07 log units) away from the limit.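

Compound 2 and compound 4 both sit at a limit of the assay rather than at a number, so no step between them can be read: the limit of < 1 nM in this assay, at which 3 of the 4 values shown sit.

Going by these compounds, whether (trifluoromethyl)carbonyl in place of methylsulfonyl changes the inhibition at all remains open.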